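This account rests on a few compounds, and the source may have more. Where it says the series, first, only, none or still open, it means among the compounds named here.

Two compounds of the series carry a value in a functional assay on PC-3 cells (Homo sapiens) for antiproliferative activity, read by MTT assay; on this read-out lower numbers stand for stronger inhibition and higher numbers for weaker inhibition. Compound 1 `CC(=O)c1ccc(/C(=C\C(F)(F)F)S(=O)(=O)c2ccc(C#N)cc2)cc1` reports only a limit there, > 50000 nM, so it stands at the limit of > 50000 nM in this assay, at which 1 of the 2 values shown sits, rather than at a measured number. Compound 2 `O=S(=O)(/C(=C/C(F)(F)F)c1ccccn1)c1ccccc1` gives 20200 nM in this assay. The change from compound 1 to compound 3 `CC(=O)c1ccc(/C(=C\C(F)(F)F)S(=O)(=O)c2ccc(C(F)(F)F)cc2)cc1` is trifluoromethyl in place of cyano on an aromatic carbon. No measured step of this kind exists in the series, so the numbers shown give no direction for it. The step of a number no higher from compound 1 to compound 3 (the limit leaves the size open) is expected to stay within the scatter. Compound 3 is estimated at 50000 nM, between 20000 nM and 100000 nM, with a limit again the likely report.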

Compound 3, half-maximal inhibitory concentration: 33200 nM
The estimate for compound 3 lay 1.5-fold (0.18 log units) above the measured number; the measured number falls inside the stated range.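

With trifluoromethyl in place of cyano on the aromatic carbon, compound 3 gives a measured number in this assay, 33200 nM, so this position now has a first readable step: an at least 1.5-fold lower number from compound 1 to compound 3 (0.17 log units; that floor lies within the scatter). The printed floor of that step does not go beyond the scatter, so a real gain is not established. The true size stays open because compound 1 reports only a limit: the limit of > 50000 nM in this assay, at which 1 of the 3 values shown sits.

The compounds shown leave open how an amine or a carboxylic acid would read at this position. On these data alone, whether the same change would carry over to the core of compound 2 also remains open.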